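Trading a Benzyl Group for a Carbamate Chain

This account rests on a few compounds, and the source may have more. Where it says the series, first, only, none or still open, it means among the compounds named here.

Measured so far:
- compound 1, `COc1ccc(-c2nc(N)n(-c3ncnc4ccccc34)n2)cc1`: > 40000 nM
- compound 2, `CCN(CC)c1nc(-n2nc(-c3ccccn3)nc2N)c2cc(OC)c(OC)cc2n1`: > 40000 nM
- compound 3, `COc1cc2ncnc(-n3nc(-c4ccccn4)nc3N)c2cc1OCc1ccccc1`: 8600 nM

Of the compounds shown here, three have been tested in an assay on MCF7 cells for inhibition of Serine-protein kinase ATM (Homo sapiens), read by immunofluorescence, with a stated time of 1 h; on this read-out lower numbers stand for stronger inhibition and higher numbers for weaker inhibition. Compound 1 gives only a limit of the assay, > 40000 nM. Compound 2 likewise gives only a limit, > 40000 nM. Among the measured compounds shown here, compound 3 is the single compound with a number, 8600 nM, and the limit of > 40000 nM in this assay, at which 2 of the 3 values shown sit, shows where the other two sit; compound 3 therefore stands alone as the only measurable value among the three.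

Compound 4, `CCOC(=O)NCCCOc1cc2c(-n3nc(-c4ccccn4)nc3N)ncnc2cc1OC`, is the next to be measured in this assay. It differs from compound 3 in one place: 2-((ethoxycarbonyl)amino)ethyl in place of phenyl on a saturated chain carbon bound to an oxygen on an aromatic ring. For the measured compounds named here, no step between measured compounds exists here to guide the expectation, so the estimate rests only on the value of compound 3 and on the size of the change. A step of about a 1.2-fold higher number from compound 3 to compound 4 (0.07 log units; within the scatter) is expected, which would leave the numbers close to where compound 3 sits, though with wide uncertainty and a real chance that only a limit is returned. The estimate for compound 4 in this assay is 10000 nM, with a range from 2000 nM to 40000 nM.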

Compound 4, half-maximal inhibitory concentration: 800 nM
Beside the measured number, compound 4's estimate is 13-fold (1.10 log units) above it; measured number outside the range, below it.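

In this assay, swapping phenyl for 2-((ethoxycarbonyl)amino)ethyl on a saturated chain carbon bound to an oxygen on an aromatic ring gives an 11-fold lower number from compound 3 to compound 4 (1.03 log units; beyond the scatter). Among the compounds shown here, until now, compound 3 held the only actual number, so nothing showed that a change at this place could shift the read-out; this step shows that it can, and by a margin well beyond the usual scatter. It also shows that the phenyl ring is not needed here for a measurable value, since the ringless carbamate chain of compound 4 gives the lower number, while measurable values remain the minority among the compounds shown: the limit of > 40000 nM in this assay, at which 2 of the 4 values shown sit.

With a single step, the gain cannot yet be assigned to one part of the new chain, whether the carbamate, its amide hydrogen, its ethyl end or simply the loss of the phenyl ring. A plain propyl chain, a chain ending in an amine or a carboxylic acid, and a longer or shorter carbamate chain would each help separate these parts, and the compounds shown say nothing about how any of them would read.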